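A few compounds are considered here, and "the series" means these few. Any claim that something is new, unique, unknown or untested is made for them only; others in the source may bear on it.

In a functional assay on HeLa cells (Homo sapiens) for inhibition, read by cell counting, with a stated time of 4 days (on this read-out higher numbers stand for weaker inhibition and lower numbers for stronger inhibition), three compounds have been measured so far:

compound 1 `COc1cccc(-c2nn3cc(-c4cccc(N)c4)nc3s2)c1` gives 230000 nM
compound 2 `C=C(Br)C(=O)Nc1cccc(-c2cn3nc(-c4ccc(C)cc4)sc3n2)c1` gives 2000 nM
compound 3 `C=C(Br)C(=O)Nc1cccc(-c2cn3c(-c4ccc(OC)cc4)csc3n2)c1` gives 860 nM

Compound 2 holds the second highest of these three numbers. Its nearest neighbour is compound 3, whose number lies lower by a margin beyond the usual scatter; compound 1 lies far higher, also beyond the scatter. Compound 4 `C=C(Br)C(=O)Nc1cccc(-c2cn3nc(-c4cccs4)sc3n2)c1` has not yet been measured. It differs from compound 2 in one place: thiophen-2-yl in place of 4-methylphenyl on an aromatic carbon. For the measured compounds named here, no step between measured compounds covers such a change, so the step in this assay is expected to be small, of no certain direction, and probably within the scatter. Compound 4 is therefore expected to give about 2500 nM, with a range from 900 nM to 7000 nM. The expected step is a 1.3-fold higher number from compound 2 to compound 4 (0.10 log units; within the scatter).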

Compound 4, half-maximal inhibitory concentration: 670 nM
Compound 4: the middle estimate sits 3.7-fold (0.57 log units) above what was measured; measured number below the stated range.
By their numbers in this assay, from the lowest: compounds 4 and 3 (each within the scatter of the next); then compound 2; then compound 1.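

In this assay, thiophen-2-yl in place of 4-methylphenyl brings a 3.0-fold lower number from compound 2 to compound 4 (0.47 log units; beyond the scatter) and so shows that this aromatic carbon, next to the ring nitrogen and next to the ring sulfur, responds to a change of group. The six-membered aromatic ring of carbon only can give way here to a five-membered aromatic ring with one hetero atom, with no loss of inhibition. Nothing measured here gives a cause for this step. Going by these compounds, what an unsubstituted phenyl, a furan-2-yl or an amine would do at this same carbon remains open.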